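This account rests on a few compounds, and the source may have more. Where it says the series, first, only, none or still open, it means among the compounds named here.

Among the compounds with values here, compound 2 `O=Cc1ccc(-c2cn3ccnc3c(-c3ccc4ncn(C5CCCCC5)c4c3)n2)cc1` is one of two compounds measured so far in a functional assay on EKVX cells (Homo sapiens) for inhibition, read by sulforhodamine B assay, with a stated time of 48 h, tested at 10 uM (a lower number here means less inhibition, a higher number more inhibition at the concentration tested (going by the name of the read-out)), and compound 2 gives 20.9%. That is the lower of the two numbers, with compound 1 `c1ccc(-c2cn3ccnc3c(-c3ccc4ncn(C5CCCCC5)c4c3)n2)cc1` nearest: compound 1 gives 24.2%, a gap within the usual scatter. Within the data shown here, the only measured step, a number 3.3 percentage points lower from compound 1 to compound 2 (within the scatter), placed a formyl where a hydrogen had been and changed the read-out by an amount within the scatter.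

Compound 3 `c1ccc2c(-c3cn4ccnc4c(-c4ccc5ncn(C6CCCCC6)c5c4)n3)cccc2c1` is not yet measured and differs from compound 2 at one place: naphthalen-1-yl in place of 4-formylphenyl on an aromatic carbon. Among the measured compounds shown here, the one known step bears on this only loosely, since here the entire 4-formylphenyl leaves and a larger two-ring group enters. With so little to go on, the expectation is a step near zero, a number 3.1 percentage points higher from compound 2 to compound 3 (within the scatter), and compound 3 is estimated at 24%, with a range from 8% to 42%.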

Compound 3, a percentage reported as inhibition, at one concentration (the size of the read-out at that concentration, not a potency): 13.3%
Beside the measured number, compound 3's estimate is 10.7 percentage points above it; measured number inside the range.
By their numbers in this assay, from the lowest: compounds 3, 2 and 1 (each within the scatter of the next, the first and the last beyond it).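

At this aromatic carbon, this assay now shows its first step beyond the usual scatter: with naphthalen-1-yl in place of phenyl, the result is a number 10.9 percentage points lower from compound 1 to compound 3 (beyond the scatter). Swapping 4-formylphenyl for naphthalen-1-yl gives a smaller step, a number 7.6 percentage points lower from compound 2 to compound 3 (within the scatter), so the second ring shows a clear effect only when the comparison starts from plain phenyl, and even there the change is modest. There is no independent measurement that accounts for this step.

The compounds shown leave open whether the loss depends on the second ring itself or on how that ring is attached, which naphthalen-2-yl could help to separate. They also leave open whether an amine or a carboxylic acid on the phenyl would move the number in either direction.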